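Swapping the amide side chain of compound 2

A few compounds are considered here, and "the series" means these few. Any claim that something is new, unique, unknown or untested is made for them only; others in the source may bear on it.

In an ADME assay on CEM-SS cells (Homo sapiens) for cytotoxicity, read by XTT assay, with a stated time of 6 days (on this read-out higher numbers stand for lower toxicity in this test and lower numbers for higher toxicity in this test), three compounds of the shared core have been examined. Compound 1 `CCCC(=O)OCSc1ccc(OC(F)(F)F)cc1C(=O)NC(C)(C)C(N)=O` gives only a limit of the assay, < 56.1 uM. Going by the values given here, compound 2 `CCCC(=O)OCSc1ccccc1C(=O)NCCCCCCNC(C)=O` gives 8 uM, the lower of the two numbers known. Compound 3 `CCCC(=O)OCSc1ccccc1C(=O)Nc1cccc(C(N)=O)c1` gives 17.5 uM, a higher number that lies beyond the usual scatter of the test. The record of limits is short: the limit of < 56.1 uM in this assay, at which 1 of the 3 values shown sits.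

Compound 4 `CCCC(=O)OCSc1ccccc1C(=O)NCC(=O)NC(C)C` has not been measured. It differs from compound 2 in one place: isopropylcarbamoyl in place of 5-acetamidopentyl on a saturated chain carbon bound to an amide-type nitrogen. Among the compounds with values here, no measured pair separates this change from others, so its effect can only be guessed from the spread of the numbers. With a shorter group on the saturated chain carbon bound to the amide-type nitrogen, the account expects a modest step upward in this assay, away from the lowest number, as a 2.5-fold higher number from compound 2 to compound 4 (0.40 log units; beyond the scatter). Compound 4 is therefore estimated at 20 uM, with a range from 7 uM to 60 uM, and a fair chance that the test reports only a limit.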

Compound 4, half-maximal toxic concentration: 92 uM
Estimate against measurement, compound 4: 4.6-fold (0.66 log units) below; measured number above the stated range.
By their numbers in this assay, from the lowest: compound 2; then compound 3; then compound 4.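

In this assay, going by these compounds alone, the change to isopropylcarbamoyl in place of 5-acetamidopentyl gives a 12-fold higher number from compound 2 to compound 4 (1.06 log units; beyond the scatter), the first readable step, and it shows that this place on a saturated chain carbon bound to an amide-type nitrogen can move the toxicity read-out by a large amount. The group that enters has the same counts of hydrogen-bond donors and acceptors as the group that leaves, and neither has a ring or a net charge, so these counts do not follow the step. Nothing in the data shown gives a cause for this step.

This single pair cannot separate the effect of the chain length from that of the end group. It also leaves open how an amine, a carboxylic acid or a longer chain at this place would read.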